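Pyrrolidine for methylpiperazine on the side chain of compound 1

This account rests on a few compounds, and the source may have more. Where it says the series, first, only, none or still open, it means among the compounds named here.

Measured so far in an ADME assay on L6 cells (Rattus norvegicus) for cytotoxicity; a lower number here means a stronger inhibitor, a higher number a weaker inhibitor:
compound 1 `CN1CCN(CCC(=O)NC2CC3(N4CCCCC4)CC(c4ccccc4)C2C(c2ccccc2)C3)CC1` gives 61100 nM
compound 2 `c1ccc(C2CC3(N4CCCCC4)CCN(CCN4CCCC4)C2C(c2ccccc2)C3)cc1` gives 156000 nM
compound 3 `CN1CCN(CCC(=O)N2CCC3(N4CCCCC4)CC(c4ccccc4)C2C(c2ccccc2)C3)CC1` gives 120000 nM

Compound 1 and compound 3 sit within the scatter of each other; compound 2 stands beyond the scatter above compound 1. Compound 4 `O=C(CN1CCCC1)NC1CC2(N3CCCCC3)CC(c3ccccc3)C1C(c1ccccc1)C2` is not yet measured. It differs from compound 1 by pyrrolidin-1-yl in place of (4-methylpiperazin-1-yl)methyl on a saturated chain carbon bound to a carbonyl carbon. Among the compounds with values here, the one measured step that swaps the same two amines, on an amine nitrogen in a ring, is a 1.3-fold lower number from compound 2 to compound 3 (0.11 log units; within the scatter), so no step beyond the scatter is anticipated here either. For compound 4 the expected outcome in this assay is 70000 nM, with a range of 30000 nM to 160000 nM. The expected step is a 1.1-fold higher number from compound 1 to compound 4 (0.06 log units; within the scatter).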

Compound 4, half-maximal inhibitory concentration: 21000 nM
Compound 4: middle estimate off by 3.3-fold (0.52 log units), on the high side; measured number below the stated range.
By their numbers in this assay, from the lowest: compound 4; then compounds 1, 3 and 2 (each within the scatter of the next, the first and the last beyond it).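

In this assay the side chain on the amide nitrogen responds to this change, with a 2.9-fold lower number from compound 1 to compound 4 (0.46 log units; beyond the scatter), whereas the swap between the same two amines on the ring nitrogen gave only a 1.3-fold lower number from compound 2 to compound 3 (0.11 log units; within the scatter). The result from the ring nitrogen therefore does not carry over to this position. The change here also shortens the link, from 2-(4-methylpiperazin-1-yl)ethyl to (pyrrolidin-1-yl)methyl, so amine and chain length change together. No measurement bears on the cause of the step. Open, going by these compounds, is whether the pyrrolidine or the shorter link carries the step, and how a morpholine on the same one-carbon link would read.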